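Swapping the Five-Membered Ring on the Shared Core

The source may report more compounds than this note shows. Statements on the series, on what has been measured and on what is new or still open speak of the compounds shown alone.

Compound 2, `Cc1noc(C)c1-c1nn(Cc2ccc(C(=O)NC3CC(C)(C)N([O])C(C)(C)C3)cc2)c(=O)c2ccccc12`, is the weaker of two measured members of this series, but only by a margin that the assay cannot reliably separate. In a functional assay on A549 cells (Homo sapiens) for antiproliferative activity, read by MTT assay, with a stated time of 72 h (on this read-out lower numbers stand for stronger inhibition and higher numbers for weaker inhibition), compound 2 gives 84300 nM. Its nearest neighbour, compound 1, `CN1CCC(NC(=O)c2ccc(Cn3nc(-c4cnn(C)c4)c4ccccc4c3=O)cc2)CC1`, carries a different amide amine as well as a different five-membered ring, and in this assay compound 1 gives 54300 nM, a difference from compound 2 that sits within the scatter of repeat measurements, so the two values are best read as the same.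

Compound 3, `Cn1cc(-c2nn(Cc3ccc(C(=O)NC4CC(C)(C)N([O])C(C)(C)C4)cc3)c(=O)c3ccccc23)cn1`, keeps the amide portion of compound 2 and changes only the five-membered ring: 1-methyl-1H-pyrazol-4-yl in place of 3,5-dimethyl-1,2-oxazol-4-yl on an aromatic carbon. Among the measured compounds shown here, no pair of measured compounds differs by exactly this change, so there is no measured step to lean on. The same pyrazole already sits on compound 1 without pushing its value beyond the scatter from compound 2. The step from compound 2 to compound 3 is therefore expected to be small, a 1.3-fold lower number from compound 2 to compound 3 (0.11 log units; within the scatter), with no direction beyond the scatter. Compound 3 is expected to give about 65000 nM in this assay, in a range from 25000 nM to 170000 nM.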

Compound 3, half-maximal inhibitory concentration: 37300 nM
Beside the measured number, compound 3's estimate is 1.7-fold (0.24 log units) above it, and the stated range covers the measured number.
By their numbers in this assay, from the lowest: compounds 3, 1 and 2 (each within the scatter of the next, the first and the last beyond it).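

Among the compounds shown here, replacing 3,5-dimethyl-1,2-oxazol-4-yl with 1-methyl-1H-pyrazol-4-yl on this aromatic carbon gives a 2.3-fold lower number from compound 2 to compound 3 (0.35 log units; beyond the scatter) in this assay, the first measured step at this position, and it shows a modest response to a swap between two rings with the same counts of hydrogen-bond donors and acceptors and no net charge. With 1-methyl-1H-pyrazol-4-yl held in place, changing the group on the amide-type nitrogen gives a 1.5-fold lower number from compound 1 to compound 3 (0.16 log units; within the scatter), so in this assay that difference cannot be told apart from the variation between repeat measurements. Nothing in the available data accounts for the step at the five-membered ring.

The compounds shown leave open whether the step follows from the identity of the ring atoms or from the methyl groups, which an unsubstituted 1H-pyrazol-4-yl or a 3-methyl-1,2-oxazol-4-yl at this position could help to separate. As far as these compounds go, it also remains open whether a six-membered ring such as pyridine or phenyl would fit the same trend, and whether the swap would give a similar step alongside the amide group of compound 1.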